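The source may hold more compounds than are shown below. What is called first, only, known or untested is meant among the compounds shown, and "the series" means these compounds.

Working notes on the series, read in a functional assay on HepG2 cells (Homo sapiens) for antiproliferative activity, read by CCK-8 assay, with a stated time of 72 h; on this read-out lower numbers stand for stronger inhibition and higher numbers for weaker inhibition. Compound 1 `Nc1ccccc1NC(=O)c1ccc(COc2ccc([N+](=O)[O-])cc2)cc1` reaches only a limit, > 32000 nM. Within the data shown here, compound 2 `CCc1ccc(OCc2ccc(C(=O)Nc3ccccc3N)cc2)cc1` gives 6960 nM, the only actual number so far. Its rank rests on a single comparison with a limit.

Compound 3 `Cc1ccc(OCc2ccc(C(=O)Nc3ccccc3N)cc2)cc1` shortens the ethyl of compound 2 to methyl: hydrogen in place of methyl on a saturated chain carbon bound to an aromatic carbon. In words, this is hydrogen in place of methyl on a saturated chain carbon bound to an aromatic carbon.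

Among the measured compounds shown here, one measured step bears on this, and only loosely: an at least 4.5-fold lower number from compound 1 to compound 2 (0.66 log units; beyond the scatter). It exchanges nitro for ethyl, not ethyl for methyl, and its size is open on one side, given (the limit of > 32000 nM in this assay, at which 1 of the 2 values shown sits). It therefore offers little guidance on size. A much smaller change is expected here, most likely with no shift beyond the scatter in this assay, and any drift is expected towards a slightly higher number. The expected move is a 1.3-fold higher number from compound 2 to compound 3 (0.11 log units; within the scatter), anchored on compound 2 at 6960 nM.

For compound 3 the estimate is 9000 nM, with an expected range of 3500 nM to 24000 nM.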

Compound 3, half-maximal inhibitory concentration: 6590 nM
Compound 3: the middle estimate sits 1.4-fold (0.14 log units) above what was measured; the range from low to high includes it.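

Shortening the 4-ethylphenyl to 4-methylphenyl leaves the read-out in this assay unchanged within the scatter: a 1.1-fold lower number from compound 2 to compound 3 (0.02 log units; within the scatter). The outer methyl of the ethyl group, on a saturated chain carbon bound to an aromatic carbon, can therefore be replaced by hydrogen with no visible shift, which compound 1 and compound 2 alone could not show. The step from nitro to methyl on an aromatic carbon, an at least 4.8-fold lower number from compound 1 to compound 3 (0.68 log units; beyond the scatter), runs the same way as an at least 4.5-fold lower number from compound 1 to compound 2 (0.66 log units; beyond the scatter), so ethyl and methyl now both stand apart from nitro, though the size of each step stays open on one side, as the value for compound 1 is a limit: the limit of > 32000 nM in this assay, at which 1 of the 3 values shown sits.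

The compounds shown leave open whether hydrogen, a longer chain such as propyl, an amine or a carboxylic acid on that aromatic carbon would keep the numbers of compound 2 and compound 3 or shift them. With only nitro, ethyl and methyl at this place, no trend across groups can be read, and no part of the shared core has been varied.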